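The source may report more compounds than this note shows. Statements on the series, on what has been measured and on what is new or still open speak of the compounds shown alone.

The shared core of compound 3 `COc1ccc2c(=O)c(/C=C/C(=O)Nc3ccc(F)cc3)coc2c1` carries an amide whose nitrogen bears a 4-fluorophenyl group. In a functional assay on HeLa cells (Homo sapiens) for inhibition, read by MTT assay, with a stated time of 48 h (a higher number here means a weaker inhibitor, a lower number a stronger inhibitor), compound 3 gives 9680 nM. Compound 2 `COc1ccc2c(=O)c(/C=C/C(=O)NCc3ccccc3)coc2c1`, in which that nitrogen bears a benzyl group instead, gives 33400 nM in this assay. Compound 1 `COc1ccc2c(=O)c(/C=C/C(=O)NCc3ccc(F)cc3)coc2c1` carries a 4-fluorobenzyl group on the same nitrogen; in this assay compound 1 gives > 100000 nM, which is a limit of the assay rather than a number (the limit of > 100000 nM in this assay, at which 1 of the 3 values shown sits). Of the two numbers shown, compound 3 has the lowest and is therefore the strongest inhibitor, with compound 2 nearest at a 3.5-fold lower number from compound 2 to compound 3 (0.54 log units; beyond the scatter). The step of an at least 10-fold lower number from compound 1 to compound 3 (1.01 log units; beyond the scatter) is larger still, and an at least 2.9-fold lower number from compound 1 to compound 2 (0.47 log units; beyond the scatter) shows that hydrogen in place of fluoro also lowered the number.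

Compound 4 `COc1ccc2c(=O)c(/C=C/C(=O)Nc3ccccc3Cl)coc2c1` differs from compound 3 by 2-chlorophenyl in place of 4-fluorophenyl on an amide-type nitrogen. Within the data shown here, none of the measured steps swaps one substituted phenyl for another; each instead exchanges a benzyl or 4-fluorobenzyl group for something else. Both compound 3 and compound 4 keep an aromatic ring directly on the amide nitrogen, so in this assay no change beyond the scatter is expected, with only a slight lean towards a weaker inhibitor. The expected step is a 1.3-fold higher number from compound 3 to compound 4 (0.13 log units; within the scatter). For compound 4 the estimate is 13000 nM, within a range from 3500 nM to 50000 nM.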

Compound 4, half-maximal inhibitory concentration: 22400 nM
Compound 4: middle estimate off by 1.7-fold (0.24 log units), on the low side; the measured number falls inside the stated range.
By their numbers in this assay, from the lowest: compound 3; then compounds 4 and 2 (each within the scatter of the next). At a limit, above all of these: compound 1.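

Among these compounds, this is the first step that swaps one substituted phenyl for another on the amide-type nitrogen, and a 2.3-fold higher number from compound 3 to compound 4 (0.36 log units; beyond the scatter) shows that the choice of substituted ring matters in this assay, even though the 4-fluorophenyl and 2-chlorophenyl groups have the same count of heavy atoms. The step of a 1.5-fold lower number from compound 2 to compound 4 (0.17 log units; within the scatter) means that the 2-chlorophenyl and benzyl groups cannot be told apart here, so an aromatic ring directly on the nitrogen does not by itself give the lower number seen with the 4-fluorophenyl group of compound 3. The step of an at least 4.4-fold lower number from compound 1 to compound 4 (0.64 log units; beyond the scatter) gives only a bound and not an exact size, as compound 1 stands at a limit of the assay: the limit of > 100000 nM in this assay, at which 1 of the 4 values shown sits.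

The 2-chlorophenyl and 4-fluorophenyl groups differ both in the halogen and in the numbered ring position that carries it, so this single step cannot say which of the two differences accounts for the change. Going by these compounds, a 4-chlorophenyl or 2-fluorophenyl group would separate those two differences, and how an unsubstituted phenyl, or a phenyl carrying an amine or a carboxylic acid, would read in this assay stays open.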